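Replacing the 3,5-difluorophenyl group of compound 2

This account rests on a few compounds, and the source may have more. Where it says the series, first, only, none or still open, it means among the compounds named here.

Measured in a functional assay on EBC-1 cells (Homo sapiens) for antiproliferative activity, with a stated time of 72 h; on this read-out lower numbers stand for stronger inhibition and higher numbers for weaker inhibition:
- compound 1 `N#Cc1cccc(-c2cc(F)c3ncc(Cc4ccc5ncccc5c4)n3c2)c1`: 107 nM
- compound 2 `Fc1cc(F)cc(-c2cc(F)c3ncc(Cc4ccc5ncccc5c4)n3c2)c1`: 790 nM

Among the measured compounds shown here, compound 2, at 790 nM, has the higher of the two numbers, and compound 1 stands at 107 nM as its only neighbour. The two compounds differ at one aromatic carbon of the shared core. That single measured step, 3,5-difluorophenyl in place of 3-cyanophenyl, is a 7.4-fold higher number from compound 1 to compound 2 (0.87 log units; beyond the scatter), and it is modest in size.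

Compound 3 `CNC(=O)c1cccc(-c2cc(F)c3ncc(Cc4ccc5ncccc5c4)n3c2)c1` has not yet been measured. It changes the same carbon again: 3-(methylcarbamoyl)phenyl in place of 3,5-difluorophenyl on an aromatic carbon, in words 3-(methylcarbamoyl)phenyl in place of 3,5-difluorophenyl on an aromatic carbon. For the measured compounds named here, no measured compound carries this amide, so the only guide is the step from the 3-cyanophenyl of compound 1. Compound 2 would then be the weaker form, and a move away from its 3,5-difluorophenyl group is expected to lower the number by a similar amount. In this assay the expected change is a 6.6-fold lower number from compound 2 to compound 3 (0.82 log units; beyond the scatter), an estimate that remains uncertain. For compound 3 the estimated value is 120 nM, with an expected range from 30 nM to 480 nM.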

Compound 3, half-maximal inhibitory concentration: 400 nM
The estimate for compound 3 lay 3.3-fold (0.52 log units) below the measured number, and the stated range covers the measured number.
By their numbers in this assay, from the lowest: compound 1; then compounds 3 and 2 (each within the scatter of the next).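

Compound 3 shows that a nitrile on the phenyl ring at this carbon cannot be swapped freely for another single substituent. In this assay, exchanging the cyano group for methylcarbamoyl gives a 3.7-fold higher number from compound 1 to compound 3 (0.57 log units; beyond the scatter), so the advantage of compound 1 over compound 2 does not carry over to this amide, and compound 1 keeps the lowest number of the three. The second step, a 2.0-fold lower number from compound 2 to compound 3 (0.30 log units; within the scatter), separates the 3-(methylcarbamoyl)phenyl group from the 3,5-difluorophenyl group by no more than the usual scatter, even though the two groups differ in their counted hydrogen-bond donors and acceptors, and nothing in hand links these differences in the numbers to any property of the groups.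

The three compounds leave open whether the amide hydrogen or the methyl group on the amide has any bearing on the number, a question that a primary carboxamide or a dimethylamide in the same place would address. They also leave open how this carbon responds to groups of other kinds on the phenyl ring, such as a carboxylic acid, an amine or a sulfonamide.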